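The source may hold more compounds than are shown below. What is called first, only, known or untested is meant among the compounds shown, and "the series" means these compounds.

In an assay on isolated protein for inhibition of glutathione S-transferase P (Homo sapiens), with a stated time of 10 min (on this read-out lower numbers stand for stronger inhibition and higher numbers for weaker inhibition), compound 1 `O=C(O)CCC(=O)OCCCCCCSc1ccc([N+](=O)[O-])c2nonc12` gives 530 nM. Compound 2 `Cc1ccc(NC(=O)CCC(=O)OCCCCCCSc2ccc([N+](=O)[O-])c3nonc23)cc1` gives 6800 nM in this assay, and compound 3 `COc1ccc(NC(=O)CCC(=O)OCCCCCCSc2ccc([N+](=O)[O-])c3nonc23)cc1OC` gives 6470 nM. Turning the acid of compound 1 into an anilide is costly: a 13-fold higher number from compound 1 to compound 2 (1.11 log units; beyond the scatter) and a 12-fold higher number from compound 1 to compound 3 (1.09 log units; beyond the scatter). Swapping one aryl group for another on the amide-type nitrogen, by contrast, changed little: a 1.1-fold lower number from compound 2 to compound 3 (0.02 log units; within the scatter). Compound 3 therefore stands second highest of the three numbers, close to compound 2 and far from compound 1.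

Compound 4 `O=C(CCC(=O)OCCCCCCSc1ccc([N+](=O)[O-])c2nonc12)Nc1ccc(F)c(Cl)c1` differs from compound 3 in one place: 3-chloro-4-fluorophenyl in place of 3,4-dimethoxyphenyl on an amide-type nitrogen. Among the measured compounds shown here, the only measured step that bears on this kind of change is the aryl swap from compound 2 to compound 3, which stayed within the scatter; the two large steps concern the loss of the hydroxy group, which compound 4 shares with compound 3. On that basis no step beyond the scatter is expected in this assay, and compound 4 is estimated at 6500 nM, between 3000 nM and 14000 nM, which would mean a 1.0-fold higher number from compound 3 to compound 4 (0.00 log units; within the scatter).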

Compound 4, half-maximal inhibitory concentration: 9850 nM
For compound 4 the middle estimate is 1.5-fold (0.18 log units) below the measured one; low and high end bracket the measured number.
By their numbers in this assay, from the lowest: compound 1; then compounds 3, 2 and 4 (each within the scatter of the next).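

In this assay, the 3-chloro-4-fluorophenyl group, which carries no hydrogen-bond acceptors, cannot be told apart from the 3,4-dimethoxyphenyl group, which carries two: the record gives a 1.5-fold higher number from compound 3 to compound 4 (0.18 log units; within the scatter) and a 1.4-fold higher number from compound 2 to compound 4 (0.16 log units; within the scatter). With three different aryl groups on the amide-type nitrogen, the anilides of compounds 2, 3 and 4 all remain well separated from the acid, and the widest of these gaps is a 19-fold higher number from compound 1 to compound 4 (1.27 log units; beyond the scatter). Nothing measured here explains why the aryl groups compared so far make so little difference or why the acid stands apart.

Going by these compounds, it remains open whether a methyl ester, a primary amide or an amine on that carbonyl carbon would stay close to the acid or to the anilides. On these data alone, the effect of a longer chain in the linker, or of a benzyl group on the amide-type nitrogen, also remains open.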